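Aryl Replacement on the Shared Core: From Formylphenyl to Naphthyl

The compounds below may be only part of what the source reports. "The series", "measured", "known", "first", "only" and "open" are said of these compounds alone.

Measured so far:
compound 1 `CCc1ccc(-c2cn3ccnc3c(-c3ccc4ncn(Cc5ccccc5)c4c3)n2)cc1` — 47.9%
compound 2 `O=Cc1ccc(-c2cn3ccnc3c(-c3ccc4ncn(Cc5ccccc5)c4c3)n2)cc1` — 56.5%

For the measured compounds named here, in a functional assay on SK-MEL-5 cells (Homo sapiens) for inhibition, read by sulforhodamine B assay, with a stated time of 48 h, tested at 10 uM (a higher number here means more inhibition at the concentration tested (going by the name of the read-out), a lower number less inhibition), compound 2 has the higher of the two numbers, but its only neighbour, compound 1, lies within the scatter of it: the step of a number 8.6 percentage points higher from compound 1 to compound 2 (within the scatter) does not separate the two.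

Compound 3 `c1ccc(Cn2cnc3ccc(-c4nc(-c5cccc6ccccc56)cn5ccnc45)cc32)cc1` is not yet measured. Relative to compound 2 the change is naphthalen-1-yl in place of 4-formylphenyl on an aromatic carbon. Going by the values given here, the one step known, formyl in place of ethyl on the aryl at this same position, was a number 8.6 percentage points higher from compound 1 to compound 2 (within the scatter) and within the scatter. Among the compounds with values here, that is the only guidance, and it concerns a smaller change than the exchange of the whole aryl ring, so the uncertainty is wider than for that step.

Compound 3 is therefore expected near 50% with a range of 28% to 72%. The step of a number 6.5 percentage points lower from compound 2 to compound 3 (within the scatter) is estimated to stay within the scatter.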

Compound 3, a percentage reported as inhibition, at one concentration (the size of the read-out at that concentration, not a potency): 9.69%
Beside the measured number, compound 3's estimate is 40.3 percentage points above it, outside the stated range (below it).
By their numbers in this assay, from the lowest: compound 3; then compounds 1 and 2 (each within the scatter of the next).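

Exchanging the whole aryl ring on the shared core has an effect in this assay that the change of substituent on the phenyl ring did not show: naphthalen-1-yl in place of 4-formylphenyl gives a number 46.8 percentage points lower from compound 2 to compound 3 (beyond the scatter) and naphthalen-1-yl in place of 4-ethylphenyl gives a number 38.2 percentage points lower from compound 1 to compound 3 (beyond the scatter) as the two steps at this position. Compound 1 and compound 2 stay within the scatter of each other, while compound 3 is separated from both, so this position responds to the identity of the ring itself and not only to what the phenyl ring carries. Nothing at hand accounts for this loss of inhibition.

Going by these compounds, it remains open whether naphthalen-2-yl would behave like naphthalen-1-yl. On these data alone, it is also open whether a phenyl ring carrying an amine or a carboxylic acid would stay level with compound 1 and compound 2.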